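This account rests on a few compounds, and the source may have more. Where it says the series, first, only, none or still open, it means among the compounds named here.

Compound 1 `CC1(C)[C@@H](CO)CC[C@@]1(C)Cn1cnc2c(Cl)ncnc21` and compound 2 `CC1(C)[C@@H](Cn2nnc3c(Cl)nc(N)nc32)CC[C@@]1(C)CO` both carry a chloro on an aromatic carbon, but the difference between their two cores is not broken down here. In an ADME assay on L1210/0 cells (Mus musculus) for cytotoxicity, with a stated time of 48 h (a higher number here means a weaker inhibitor, a lower number a stronger inhibitor), compound 1 gives 42800 nM. Compound 2 gives 44600 nM in this assay, and the two values lie within the usual scatter of each other. Compound 3 `CC1(C)[C@@H](Cn2nnc3c(N)nc(N)nc32)CC[C@@]1(C)CO` differs from compound 2 by one change, (amino in place of chloro on an aromatic carbon). In this assay compound 3 reaches only a limit of the assay, > 200000 nM, so its value is not a number. The step of an at least 4.4-fold higher number from compound 2 to compound 3 (0.65 log units; beyond the scatter) is thus at least modest, and it ends at the limit (the limit of > 200000 nM in this assay, at which 1 of the 3 values shown sits). Compound 4 `CC1(C)[C@@H](CO)CC[C@@]1(C)Cn1cnc2c(N)ncnc21`, not yet measured, carries the same kind of change relative to compound 1, (amino in place of chloro on an aromatic carbon). Around the place, the change in compound 3 is also meta to an amino group (1 heavy atom), which the place in compound 4 is not, so the two changes are the same kind and not the same. Among the measured compounds shown here, the estimated step of a 4.2-fold higher number from compound 1 to compound 4 (0.62 log units; beyond the scatter) rests on an at least 4.4-fold higher number from compound 2 to compound 3 (0.65 log units; beyond the scatter) as the one measured instance of this kind of change, and it is expected to be of similar size. Compound 4 is therefore expected to give about 180000 nM in this assay, in a range from 60000 nM to 400000 nM, and the assay may well again report only a limit.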

Compound 4, half-maximal inhibitory concentration: > 200000 nM
Compound 4: a limit, no number; the forecaster's own chance of this, stated with the estimate: 55%; at least 1.1-fold (0.04 log units) between middle value and limit.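

In this assay compound 4 gives > 200000 nM, which is a limit of the assay and not a number. On the core of compound 1, amino in place of chloro on an aromatic carbon gives an at least 4.6-fold higher number from compound 1 to compound 4 (0.66 log units; beyond the scatter), so the direction of the change carries over between the two cores shown, with each amino compound ending at the limit of the assay and neither chloro compound doing so. This does not show that the size of the step carries over as well, and the true size of each step remains unknown, so no difference between the two cores can be read from them: the same change on two cores in this assay, an at least 4.4-fold higher number (0.65 log units; beyond the scatter) from compound 2 to compound 3 and an at least 4.6-fold higher number (0.66 log units; beyond the scatter) from compound 1 to compound 4; the limit leaves it open whether they differ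

The compounds shown leave open what other groups on the same aromatic carbon would do, for example a methoxy, a methylamino or a fluoro, and whether any of them would give a value that can be read as a number in this assay. They also leave open how far the result depends on the rest of the molecule, such as a carboxylic acid or a longer chain in place of the hydroxymethyl group.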